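Chloro in place of fluoro: expecting compound 4

The compounds below may be only part of what the source reports. "The series", "measured", "known", "first", "only" and "open" are said of these compounds alone.

In a functional assay on MCF7 cells (Homo sapiens) for antiproliferative activity, read by MTT assay, with a stated time of 24 h (a higher number here means a weaker inhibitor, a lower number a stronger inhibitor), compound 3 `O=S(=O)(c1ccc(F)cc1)n1c(-c2cn(-c3ccccc3)nc2-c2ccc(F)cc2)nc2ccccc21` gives 3670 nM. That value lies within the scatter of compound 1 `Cc1ccc(-c2nn(-c3ccccc3)cc2-c2nc3ccccc3n2S(=O)(=O)c2ccc(Cl)cc2)cc1` at 5930 nM, while compound 2 `O=S(=O)(c1ccccc1)n1c(-c2cn(-c3ccccc3)nc2-c2ccc(F)cc2)nc2ccccc21` gives 690 nM. Among the measured compounds shown here, the one measured step, a 5.3-fold higher number from compound 2 to compound 3 (0.73 log units; beyond the scatter), came with fluoro in place of hydrogen on an aromatic carbon, and it lies beyond the scatter. Compound 4 `O=S(=O)(c1ccc(Cl)cc1)n1c(-c2cn(-c3ccccc3)nc2-c2ccc(F)cc2)nc2ccccc21` carries chloro in place of fluoro at that same carbon, para to a large group (chloro in place of fluoro on an aromatic carbon). Compound 1, at 5930 nM, also carries the (4-chlorophenyl)sulfonyl group, though it differs elsewhere. The expected change is therefore none beyond the scatter, an estimated 1.1-fold higher number from compound 3 to compound 4 (0.06 log units; within the scatter). Compound 4 is estimated at 4200 nM, with an expected range of 1700 nM to 9000 nM.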

Compound 4, half-maximal inhibitory concentration: 4960 nM
Compound 4: middle estimate off by 1.2-fold (0.07 log units), on the low side; the measured number falls inside the stated range.
By their numbers in this assay, from the lowest: compound 2; then compounds 3, 4 and 1 (each within the scatter of the next).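

In this assay, the step of a 1.4-fold higher number from compound 3 to compound 4 (0.13 log units; within the scatter) shows that chloro and fluoro are not told apart at this carbon, while the step of a 7.2-fold higher number from compound 2 to compound 4 (0.86 log units; beyond the scatter) shows that chloro, like fluoro, stands clearly apart from hydrogen there. With the (4-chlorophenyl)sulfonyl group held constant, the step of a 1.2-fold lower number from compound 1 to compound 4 (0.08 log units; within the scatter) shows that fluoro in place of methyl elsewhere on the molecule also stays within the scatter. No available evidence accounts for the gap between the halogens and hydrogen. On these data alone, whether a methoxy group or an amine at this carbon would give numbers like those of the halogens or that of hydrogen remains open.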